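Swapping the aryl group on a chalcone-amide: Vero cell toxicity

The compounds below may be only part of what the source reports. "The series", "measured", "known", "first", "only" and "open" are said of these compounds alone.

Measured so far in an ADME assay on Vero cells (Chlorocebus sabaeus) for cytotoxicity, read by MTT assay, with a stated time of 72 h; on this read-out lower numbers stand for higher toxicity in this test and higher numbers for lower toxicity in this test:
- compound 1, `COC(=O)c1cc(-c2cccc(NC(=O)c3ccc(/C=C/C(=O)c4ccc(C)c([N+](=O)[O-])c4)cc3)c2)on1`, gives > 80 ug/mL, which is a limit of the assay rather than a number.
- compound 2, `COC(=O)c1cc(-c2cccc(NC(=O)c3ccc(/C=C/C(=O)c4ccc(CC(C)C)cc4)cc3)c2)on1`, gives > 10 ug/mL, again a limit of the assay.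
- compound 3, `CCOC(=O)c1nnn(-c2cccc(NC(=O)c3ccc(/C=C/C(=O)c4ccc(Cl)cc4)cc3)c2)c1C`, gives "not determined" (no result reported), so no result is reported for it.

Within the data shown here, compound 1 therefore stands only at a limit of the assay, and the one other value shown is a limit too, so no single number is known for any compound here. Among the measured compounds shown here, the one step between measured compounds, a step that the two limits leave unreadable from compound 1 to compound 2, cannot be read because both ends are limits; the two limits involved are the limit of > 80 ug/mL in this assay, at which 1 of the 3 values shown sits, and (the limit of > 10 ug/mL in this assay, at which 1 of the 3 values shown sits).

Compound 4, `COC(=O)c1cc(-c2cccc(NC(=O)c3ccc(/C=C/C(=O)c4cc(OC)c(OC)c(OC)c4)cc3)c2)on1`, carries the change (3,4,5-trimethoxyphenyl in place of 4-methyl-3-nitrophenyl on a carbonyl carbon). For the measured compounds named here, no measured step bears on this change with a readable size, so the expectation rests only on where compound 1 sits. Since compound 1 reaches (the limit of > 80 ug/mL in this assay, at which 1 of the 3 values shown sits), compound 4 is expected to show no step beyond the scatter, a number no higher from compound 1 to compound 4 (the limit leaves the size open), and is estimated at 80 ug/mL, within 20 ug/mL to 200 ug/mL, with a real chance that only a limit is reported again.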

Compound 4, half-maximal cytotoxic concentration: > 50 ug/mL
Compound 4 was reported as a limit (the forecaster's own chance of this, stated with the estimate: 60%); the middle value does not contradict the limit.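

Compound 4, like compound 1 and compound 2, stands only at a limit in this assay, and the steps from compound 1 to compound 4 and from compound 2 to compound 4 cannot be read. Whether changing the aryl group on the carbonyl carbon alters toxicity in this assay at all stays open; no compound shown has a single number.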